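Acylsulfonamide in Place of Sulfonamide: Oral Exposure Outlook

The compounds below may be only part of what the source reports. "The series", "measured", "known", "first", "only" and "open" are said of these compounds alone.

Measured compounds:
compound 1 `C[C@H](c1ccc(-c2cc(Cl)ccc2-c2nc(=O)o[nH]2)cc1)N(CC1CC1)c1nc2c(C(=O)O)cccc2o1` gives 1300 ng.h/mL
compound 2 `CCCCN(c1nc2c(NS(C)(=O)=O)cccc2o1)[C@H](C)c1ccc(-c2ccccc2-c2nnn[nH]2)cc1` gives 73.8 ng.h/mL

Of the compounds shown here, two have been measured in an ADME assay on the whole organism (Macaca fascicularis) for pharmacokinetics, read by LC-MS, using cassette dosing, at a dose of 1 mg/kg by the oral route; a lower number here means less compound in the circulation, a higher number more compound in the circulation at the dose given. Compound 1 gives 1300 ng.h/mL in this assay, while compound 2 gives 73.8 ng.h/mL, the lower of the two numbers, and the gap between them lies beyond the usual scatter. The two differ in several places at once, so no single structural cause can be read from that gap.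

Compound 3 `CCCCN(c1nc2c(C(=O)NS(C)(=O)=O)cccc2o1)[C@H](C)c1ccc(-c2ccccc2-c2nnn[nH]2)cc1` has not yet been measured. It differs from compound 2 in one place: (methylsulfonyl)carbamoyl in place of methanesulfonamido on an aromatic carbon. Among the measured compounds shown here, the change is small in size and leaves the rest of the structure untouched, and nothing among the measured compounds isolates this particular change. The step from compound 2 to compound 3 is therefore expected to be modest, with a 1.2-fold higher number from compound 2 to compound 3 (0.09 log units; within the scatter) as the estimated shift in this assay, a move that may not exceed the scatter. Compound 3 is estimated at 90 ng.h/mL, with a likely range from 25 ng.h/mL to 320 ng.h/mL.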

Compound 3, area under the concentration-time curve: 22.2 ng.h/mL
Compound 3: middle estimate off by 4.1-fold (0.61 log units), on the high side, outside the stated range (below it).
By their numbers in this assay, from the lowest: compound 3; then compound 2; then compound 1.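

In this assay, putting (methylsulfonyl)carbamoyl in place of methanesulfonamido on an aromatic carbon gives a 3.3-fold lower number from compound 2 to compound 3 (0.52 log units; beyond the scatter), a step beyond the scatter and in the downward direction. Among the compounds shown here, the rest of the structure is unchanged, so this is the first comparison here that ties a shift in the number to this one position, and it shows that the number responds to the group placed there. Nothing shown explains why the number falls with this change.

As far as these compounds go, whether a plain carboxamide or an amine on this aromatic carbon would give a higher or lower number than methanesulfonamido remains open. From the compounds shown here alone, it is also open whether the same exchange would give a step of similar size and direction on the structure of compound 1, which differs from both in several places.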